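Chloro in place of methoxy on the aryl ring

The source may report more compounds than this note shows. Statements on the series, on what has been measured and on what is new or still open speak of the compounds shown alone.

Of the compounds shown here, three sharing one core have been measured in an assay on HEK-293T cells for displacement of a labelled ligand from corticotropin-releasing factor receptor 1 (Homo sapiens), read by scintillation counting, with a stated time of 2 h; on this read-out higher numbers stand for weaker inhibition and lower numbers for stronger inhibition. Compound 1 `CCCCN(CC)c1cc(C)nc2c1NC(=O)CN2c1ccc(C)cc1C` gives 3.9 nM, compound 2 `CCCCN(CC)c1cc(C)nc2c1NC(=O)CN2c1ccc(C)cc1Br` gives 4.4 nM, and compound 3 `CCCCN(CC)c1cc(C)nc2c1NC(=O)CN2c1ccc(OC)cc1C` gives 4 nM. Compound 3 stands close to both others: a 1.0-fold higher number from compound 1 to compound 3 (0.01 log units; within the scatter) and a 1.1-fold lower number from compound 2 to compound 3 (0.04 log units; within the scatter). Compound 4 `CCCCN(CC)c1cc(C)nc2c1NC(=O)CN2c1ccc(Cl)cc1C` differs from compound 3 by chloro in place of methoxy on an aromatic carbon. The changes already made on this ring, a 1.1-fold higher number from compound 1 to compound 2 (0.05 log units; within the scatter) and a 1.0-fold higher number from compound 1 to compound 3 (0.01 log units; within the scatter), both stayed within the scatter, so for this assay no step beyond the scatter is expected, a 1.1-fold higher number from compound 3 to compound 4 (0.02 log units; within the scatter). Compound 4 is estimated at 4.2 nM, with a range from 2 nM to 9 nM.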

Compound 4, inhibition constant: 5.4 nM
Compound 4: the middle estimate sits 1.3-fold (0.11 log units) below what was measured; the measured number falls inside the stated range.
By their numbers in this assay, from the lowest: compounds 1, 3, 2 and 4 (each within the scatter of the next).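

This position, para to a large group, now carries chloro as well as methoxy and methyl, and in this assay chloro in place of methoxy stays within the scatter (a 1.4-fold higher number from compound 3 to compound 4 (0.13 log units; within the scatter)), as does chloro in place of methyl (a 1.4-fold higher number from compound 1 to compound 4 (0.14 log units; within the scatter)). The 4-chloro-2-methylphenyl compound also stays within the scatter of the 2-bromo-4-methylphenyl compound (a 1.2-fold higher number from compound 2 to compound 4 (0.09 log units; within the scatter)), and the loss of the hydrogen-bond acceptor of methoxy brings no step beyond it. Nothing given here explains this. The compounds shown leave open whether an amine, a carboxylic acid or a longer chain at this position would also stay within the scatter.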